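This account rests on a few compounds, and the source may have more. Where it says the series, first, only, none or still open, it means among the compounds named here.

Measured so far:
- compound 1, `COc1cc(/C=C/C(=O)/C=C/c2ccccc2)ccc1OCc1cn(CCCCOc2cc(=O)oc3ccccc23)nn1`: 36%
- compound 2, `COc1cc(/C=C/C(=O)/C=C/c2ccco2)ccc1OCc1cn(CCCCOc2cc(=O)oc3ccccc23)nn1`: 49%
- compound 3, `COc1cc(/C=C/C(=O)/C=C/c2ccccc2)ccc1OCc1cn(CCOc2cc(=O)oc3ccccc23)nn1`: 61%

All three were run in a functional assay on THP-1 cells (Homo sapiens) for inhibition, read by sulforhodamine B assay, with a stated time of 48 h, tested at 50 uM; a higher number here means more inhibition of growth at the concentration tested, a lower number less inhibition of growth. Compound 3 stands highest of the three, and its gaps to compound 2 and to compound 1 are both beyond the scatter. The difference between the core of compound 3 and the core of compound 1 is not broken down here.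

Within the core of compound 1, one change has been measured: furan-2-yl in place of phenyl on a double-bonded chain carbon bound to a double-bonded chain carbon. It gave a number 13 percentage points higher from compound 1 to compound 2 (beyond the scatter).

Compound 4, `COc1cc(/C=C/C(=O)/C=C/c2ccco2)ccc1OCc1cn(CCOc2cc(=O)oc3ccccc23)nn1`, is not yet measured. It relates to compound 3 by furan-2-yl in place of phenyl on a double-bonded chain carbon bound to a double-bonded chain carbon. The place is the same in both pairs, so this is the same change, now made on the core of compound 3 rather than on the core of compound 1.

Among the measured compounds shown here, with only one earlier instance, the expectation for compound 4 rests on the modest gain seen in a number 13 percentage points higher from compound 1 to compound 2 (beyond the scatter) applied to the value of compound 3, 61%; a step of about a number 11 percentage points higher from compound 3 to compound 4 (beyond the scatter) is expected, with wide uncertainty because only one pair supports it. Compound 4 is therefore estimated at 72% in this assay, with a range from 58% to 86%.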

Compound 4, percent growth inhibition at one concentration: 78%
Compound 4: middle estimate off by 6 percentage points, on the low side; the range from low to high includes it.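

In this assay, furan-2-yl in place of phenyl on a double-bonded chain carbon bound to a double-bonded chain carbon again raises growth inhibition, giving a number 17 percentage points higher from compound 3 to compound 4 (beyond the scatter). Set beside the earlier pair, the change carries from one core to the other in direction, and its size cannot be told apart between the two: the same change on two cores in this assay, a number 13 percentage points higher (beyond the scatter) from compound 1 to compound 2 and a number 17 percentage points higher (beyond the scatter) from compound 3 to compound 4, 4 percentage points apart, within the scatter of two such steps This rests on two cores and on one concentration in one cell line, so it does not show that the step holds on any other core, nor does it explain how the change acts.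

The compounds shown leave open whether thiophen-2-yl or pyridin-2-yl in the same place would give a similar step. Also open, as far as these compounds go, is whether furan-2-yl keeps its step on a core carrying an amine or a carboxylic acid on the chain that links the shared parts.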